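Swapping the methylphenyl arm for a methylindazole

The source may report more compounds than this note shows. Statements on the series, on what has been measured and on what is new or still open speak of the compounds shown alone.

Measured so far:
Compound 1, `COc1cc(-c2ccnc3cc(-c4ccc(C)cc4)nn23)cc(OC)c1OC`: 21 nM
Compound 2, `COc1cc(-c2ccnc3cc(-c4ccc5cc[nH]c5c4)nn23)cc(OC)c1OC`: 125 nM
Compound 3, `COc1cc(-c2ccnc3cc(-c4cccc(C)c4)nn23)cc(OC)c1OC`: 4230 nM

Of the compounds shown here, three sharing one core have been tested in a functional assay on HeLa cells (Homo sapiens) for inhibition, read by CCK-8 assay, with a stated time of 48 h; a lower number here means a stronger inhibitor, a higher number a weaker inhibitor. Compound 1 stands lowest of the three numbers, which here means the strongest inhibitor. Compound 2 is nearest to it: a 6.0-fold higher number from compound 1 to compound 2 (0.77 log units; beyond the scatter). Compound 3 is furthest: a 200-fold higher number from compound 1 to compound 3 (2.30 log units; beyond the scatter). Between the other two, a 34-fold higher number from compound 2 to compound 3 (1.53 log units; beyond the scatter).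

Compound 4, `COc1cc(-c2ccnc3cc(-c4ccc5cnn(C)c5c4)nn23)cc(OC)c1OC`, has not yet been measured. It differs from compound 1 in one place: 1-methyl-1H-indazol-6-yl in place of 4-methylphenyl on an aromatic carbon. Among the groups tried, 1H-indol-6-yl is the closest relative of 1-methyl-1H-indazol-6-yl. Among the measured compounds shown here, of the measured steps, the one from compound 1 to compound 2 therefore bears most on this change, and that step was a modest weakening. The step to compound 3 shows that a change at this arm can cost far more, but 3-methylphenyl is a different kind of change. A modest weakening is therefore expected, a 7.1-fold higher number from compound 1 to compound 4 (0.85 log units; beyond the scatter). Compound 4 is estimated at 150 nM, within 40 nM to 600 nM.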

Compound 4, half-maximal inhibitory concentration: 97 nM
Compound 4: the middle estimate sits 1.5-fold (0.19 log units) above what was measured, within the range that was stated.
By their numbers in this assay, from the lowest: compound 1; then compounds 4 and 2 (each within the scatter of the next); then compound 3.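

In this assay, a second two-ring arm, 1-methyl-1H-indazol-6-yl, replaces 4-methylphenyl at only a modest cost, with a 4.6-fold higher number from compound 1 to compound 4 (0.66 log units; beyond the scatter), so that cost is not peculiar to 1H-indol-6-yl. The two two-ring arms cannot be told apart here, with a 1.3-fold lower number from compound 2 to compound 4 (0.11 log units; within the scatter), even though 1-methyl-1H-indazol-6-yl carries 2 ring nitrogens and a methyl group. This arm also stands well clear of the poor 3-methylphenyl result, with a 44-fold lower number from compound 3 to compound 4 (1.64 log units; beyond the scatter), showing that this position can take a group of 10 heavy atoms and retain much of the activity.

Nothing shown explains why these arms differ. As far as these compounds go, it also remains open whether an amine or a carboxylic acid in place of the methyl of 1-methyl-1H-indazol-6-yl would keep the number close to that of compound 4.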